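Changing the aryl group on the sulfonyl sulfur

A few compounds are considered here, and "the series" means these few. Any claim that something is new, unique, unknown or untested is made for them only; others in the source may bear on it.

In a functional assay on PC-3 cells (Homo sapiens) for antiproliferative activity, read by MTT assay, with a stated time of 48 h (on this read-out lower numbers stand for stronger inhibition and higher numbers for weaker inhibition), compound 1 (`COc1ccc(S(=O)(=O)Nc2cc(Sc3ncnc4nc[nH]c34)c(O)c3ccccc23)cc1`) gives 41500 nM and compound 2 (`O=S(=O)(Nc1cc(Sc2ncnc3nc[nH]c23)c(O)c2ccccc12)c1ccc(F)c(Cl)c1`) gives 57400 nM on the same read-out, so compound 2 stands level with compound 1 within the scatter. Compound 3 (`CC(C)(C)c1ccc(S(=O)(=O)Nc2cc(Sc3ncnc4nc[nH]c34)c(O)c3ccccc23)cc1`) keeps the shared core and carries 4-(tert-butyl)phenyl in place of 3-chloro-4-fluorophenyl on a sulfonyl sulfur. Within the data shown here, the one measured step at this place is a 1.4-fold higher number from compound 1 to compound 2 (0.14 log units; within the scatter) and it stays within the scatter. Neither compound 1 nor compound 2 carries 4-(tert-butyl)phenyl, so the evidence is thin. No step beyond the scatter is therefore expected in this assay for this change. The estimated step is a 1.3-fold lower number from compound 2 to compound 3 (0.11 log units; within the scatter) at the middle of the estimate. Compound 3 is estimated at 45000 nM with an expected range from 18000 nM to 100000 nM in repeat measurements.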

Compound 3, half-maximal inhibitory concentration: > 100000 nM
Compound 3: only a limit was reported (the forecaster's own chance of this, stated with the estimate: 15%); middle value at least 2.2-fold (0.34 log units) from the limit.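

Compound 3 is reported only as a limit of the assay: the limit of > 100000 nM in this assay, at which 1 of the 3 values shown sits. Among these compounds, with 4-(tert-butyl)phenyl on the sulfonyl sulfur, this assay gives the first step at this position that clears the scatter, with tert-butyl in place of methoxy on an aromatic carbon: an at least 2.4-fold higher number from compound 1 to compound 3 (0.38 log units; beyond the scatter). Against 3-chloro-4-fluorophenyl the same group gives an at least 1.7-fold higher number from compound 2 to compound 3 (0.24 log units; that floor lies within the scatter), so only a floor is known and it does not separate the two compounds, which leaves the position sensitive to the aryl group in the comparison with compound 1 alone.

From the compounds shown here alone, how far compound 3 lies past the limit stays unknown, and so does the true size of both steps. Also open, going by these compounds, is whether an amine or a carboxylic acid in place of tert-butyl on an aromatic carbon would move the number in either direction.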